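The compounds below may be only part of what the source reports. "The series", "measured", "known", "first", "only" and "open" are said of these compounds alone.

Measured compounds:
- compound 1, `Cc1cc(=O)oc2cc(OCc3nc(N)nc(Nc4ccc(F)cc4)n3)ccc12`: 18300 nM
- compound 2, `Cc1ccc(Nc2nc(N)nc(COc3ccc4c(C)cc(=O)oc4c3)n2)cc1`: 1790 nM
- compound 3, `Cc1ccc(Nc2nc(N)nc(COc3cccc(N4CCCC4=O)c3F)n2)cc1Cl`: 14100 nM

All three were tested in an assay on COS-7 cells for agonist activity at Free fatty acid receptor 1 (Homo sapiens), read by scintillation counting and inositol phosphate accumulation, with a stated time of 90 min; on this read-out higher numbers stand for an effect only at larger amounts of compound and lower numbers for an effect already at smaller amounts. Compound 1 and compound 2 share a core and differ in one place, (methyl in place of fluoro on an aromatic carbon); this gave a 10-fold lower number from compound 1 to compound 2 (1.01 log units; beyond the scatter). Compound 3 carries a different core, and the difference between the two cores is not broken down here; in this assay compound 3 gives 14100 nM and compound 1 gives 18300 nM, the two lying within the usual scatter of each other.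

Compound 4, `Cc1ccc(Nc2nc(N)nc(COc3cccc(N4CCCC4=O)c3C)n2)cc1Cl`, has not yet been measured. It differs from compound 3 by methyl in place of fluoro on an aromatic carbon. Among the compounds with values here, this is the same kind of change as the one from compound 1 to compound 2, but not the same change: there the place was para to a large group, here it is ortho to a 2-oxopyrrolidin-1-yl group and ortho to a large group. Within the data shown here, only one measured example of this change exists, and it sits on another core and at another place, so the step from compound 3 to compound 4 in this assay is expected to be a 2.8-fold lower number from compound 3 to compound 4 (0.45 log units; beyond the scatter), smaller than the earlier one because of the different surroundings and the size of a 10-fold lower number from compound 1 to compound 2 (1.01 log units; beyond the scatter), which is taken as the upper bound of what the change can do. Compound 4 is therefore estimated at 5000 nM, with a range of 1500 nM to 15000 nM.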

Compound 4, half-maximal effective concentration: 11100 nM
The estimate for compound 4 lay 2.2-fold (0.35 log units) below the measured number; measured number inside the range.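

In this assay, methyl in place of fluoro on an aromatic carbon gives a 1.3-fold lower number from compound 3 to compound 4 (0.10 log units; within the scatter), so here the change has no readable effect, whereas the earlier example gave a 10-fold lower number from compound 1 to compound 2 (1.01 log units; beyond the scatter). The size of the step therefore did not carry over from one core to the other in this series, and a large step on one core gave no guide to the step on the other: the same change on two cores in this assay, a 10-fold lower number (1.01 log units; beyond the scatter) from compound 1 to compound 2 and a 1.3-fold lower number (0.10 log units; within the scatter) from compound 3 to compound 4, 8.0-fold (0.91 log units) apart, beyond the scatter of two such steps

This does not show what sets the two steps apart, since the pairs differ both in core and in the place of the change, here ortho to a 2-oxopyrrolidin-1-yl group and ortho to a large group, and two pairs cannot separate these factors or support a rule for further cores.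

The compounds shown leave open whether the small step holds for other groups on the same aromatic carbon, such as chloro, methoxy or a nitrile, and whether the large step recurs when methyl replaces fluoro elsewhere on the same core. Also open, as far as these compounds go, is whether swapping the 2-oxopyrrolidin-1-yl group for an amine or a carboxylic acid would alter the step from fluoro to methyl.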